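Aminomethyl Replaces Nitro on a Kinase-Inhibitor Amide

The source may report more compounds than this note shows. Statements on the series, on what has been measured and on what is new or still open speak of the compounds shown alone.

Compound 1 `CCCC(=O)Nc1cccc(NC(=O)COc2ccc3c(=O)ccoc3c2)c1`: 176 nM
Compound 2 `O=C(COc1ccc2c(=O)ccoc2c1)Nc1cccc(NC(=O)c2ccc([N+](=O)[O-])cc2)c1`: 15 nM

Within the data shown here, in an assay on isolated protein for inhibition of Rho-associated protein kinase 2 (Homo sapiens), read by scintillation counting, radiometric assay and 33P incorporation, with a stated time of 40 min, in the presence of a further agent that is not named here (on this read-out higher numbers stand for weaker inhibition and lower numbers for stronger inhibition), compound 2 gives 15 nM, the lowest of the two numbers; the only measured step, a 12-fold lower number from compound 1 to compound 2 (1.07 log units; beyond the scatter), swapped 4-nitrophenyl for propyl on a carbonyl carbon. Compound 3 `NCc1ccc(C(=O)Nc2cccc(NC(=O)COc3ccc4c(=O)ccoc4c3)c2)cc1` differs from compound 2 by aminomethyl in place of nitro on an aromatic carbon. Among the measured compounds shown here, no measured step touches this group, so the large step above gives no direct guide. With nothing to point either way, the expected step is a 1.3-fold higher number from compound 2 to compound 3 (0.12 log units; within the scatter), no larger than the usual scatter. Compound 3 is therefore estimated at 20 nM, most likely between 5 nM and 80 nM.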

Compound 3, half-maximal inhibitory concentration: 66 nM
Compound 3: middle estimate off by 3.3-fold (0.52 log units), on the low side; measured number inside the range.
By their numbers in this assay, from the lowest: compound 2; then compound 3; then compound 1.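

In this assay, the group on this aromatic ring clearly matters: aminomethyl in place of nitro brings a 4.4-fold higher number from compound 2 to compound 3 (0.64 log units; beyond the scatter) in the inhibition read-out. Even so, 4-(aminomethyl)phenyl in place of propyl brings a 2.7-fold lower number from compound 1 to compound 3 (0.43 log units; beyond the scatter) on the same read-out, so part of the gain seen with 4-nitrophenyl remains. No measurement here explains why the two groups differ. Still open, from the compounds shown here alone, is how a nitrile, a carboxylic acid or an amine set directly on the ring would compare with nitro and aminomethyl at this place.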